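A few compounds are considered here, and "the series" means these few. Any claim that something is new, unique, unknown or untested is made for them only; others in the source may bear on it.

Going by the values given here, in a functional assay on Bel-7402 cells (Homo sapiens) for antiproliferative activity, with a stated time of 72 h (on this read-out higher numbers stand for weaker inhibition and lower numbers for stronger inhibition), compound 1 (`COc1cc(OC)c(C(=O)/C=C/c2ccccc2Cl)c(O)c1CN1CCCCC1`) gives 3100 nM and stands lowest of the two numbers so far, with compound 2 (`CCN(C)Cc1c(OC)cc(OC)c(C(=O)/C=C/c2ccccc2Cl)c1O`) at 23300 nM as its nearest neighbour. Compound 3 (`COc1cc(OC)c(C(=O)/C=C/c2ccccc2Cl)c(O)c1CN(C)CCCN(C)C`) awaits measurement and differs from compound 1 by (3-(dimethylamino)propyl)(methyl)amino in place of piperidin-1-yl on a saturated chain carbon bound to an aromatic carbon in all. Among the compounds with values here, compound 2 is the only guide at this place, with a 7.5-fold higher number from compound 1 to compound 2 (0.88 log units; beyond the scatter) on going from piperidin-1-yl to ethyl(methyl)amino, so a rise of similar or smaller size is expected in this assay for a replacement that also has no ring. The expected step is a 3.2-fold higher number from compound 1 to compound 3 (0.51 log units; beyond the scatter) for this change. The estimated value for compound 3 is 10000 nM within a range from 3000 nM to 30000 nM as expected.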

Compound 3, half-maximal inhibitory concentration: 30900 nM
Compound 3: the middle estimate sits 3.1-fold (0.49 log units) below what was measured; the measured number lies above the stated range.
By their numbers in this assay, from the lowest: compound 1; then compounds 2 and 3 (each within the scatter of the next).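

In this assay, there is a 10-fold higher number from compound 1 to compound 3 (1.00 log units; beyond the scatter) and so a second replacement with no ring also gives a higher number than the piperidin-1-yl of compound 1. The (dimethylamino)methyl in place of hydrogen gives a 1.3-fold higher number from compound 2 to compound 3 (0.12 log units; within the scatter) and so does not separate these two compounds. Nothing given here accounts for these numbers. The compounds shown leave open whether another ring at this place, such as morpholine, piperazine or pyrrolidine, would stay close to compound 1 or rise as the ring-free amines do.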